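The source may hold more compounds than are shown below. What is called first, only, known or untested is meant among the compounds shown, and "the series" means these compounds.

Working notes on the arylurea series. Compound 1 `CCCc1ccc(NC(=O)N[C@@H](C)c2ccccc2)cc1` is the reference point: in an ADME assay on the whole organism with Oryza sativa as the target, tested at 10 uM (on this read-out lower numbers stand for a stronger effect and higher numbers for a weaker effect at the one concentration tested), compound 1 gives 73%. Compound 2 `C[C@H](NC(=O)Nc1ccc(C(C)(C)C)cc1)c1ccccc1` gives 64%, and the step of a number 9 percentage points lower from compound 1 to compound 2 (within the scatter) does not separate the two. Compound 3 `C[C@H](NC(=O)Nc1ccc(Br)cc1)c1ccccc1` gives 96%, the highest of the three numbers; it stands apart from compound 1 by a number 23 percentage points higher from compound 1 to compound 3 (beyond the scatter) and from compound 2 by a number 32 percentage points higher from compound 2 to compound 3 (beyond the scatter), so on this read-out compound 3 shows the weakest effect of the three measured.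

Compound 4 `C[C@H](NC(=O)Nc1ccc(I)cc1)c1ccccc1` is the next member. iodo in place of bromo on an aromatic carbon Both groups sit on an aromatic carbon of a six-membered aromatic ring of carbon only. The measured steps that bear on this position are the step from compound 1 to compound 3 and the step from compound 2 to compound 3, both of which exchange a branched or straight alkyl for bromo and both of which move the number upward. Within the data shown here, no measured step exchanges bromo for iodo, so the size of this step is not anchored. The closest analogy is compound 3 itself, and the expectation is a step of a number 5 percentage points lower from compound 3 to compound 4 (within the scatter), within the scatter. Compound 4 is therefore estimated at 91%, with a range from 72% to 104%.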

Compound 4, a percentage reported as activity, at one concentration (the size of the read-out at that concentration, not a potency): 95%
Compound 4: middle estimate off by 4 percentage points, on the low side, within the range that was stated.
By their numbers in this assay, from the lowest: compounds 2 and 1 (each within the scatter of the next); then compounds 4 and 3 (each within the scatter of the next).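

In this assay, iodo in place of bromo on an aromatic carbon para to a large group gives a number 1 percentage points lower from compound 3 to compound 4 (within the scatter), so this exchange of one halogen for the other does not separate the two compounds. The gap that bromo opened against the alkyl groups also appears with iodo, as a number 22 percentage points higher from compound 1 to compound 4 (beyond the scatter) and a number 31 percentage points higher from compound 2 to compound 4 (beyond the scatter), so across the four compounds shown both halogens stand beyond the scatter from both the propyl and the tert-butyl compound, and none of the four goes against this split. Nothing available bears on what lies behind this split between the alkyl and halogen groups.

Whether the split holds beyond these four groups stays open, since the compounds shown do not tell where chloro, methoxy or an amine on the same aromatic carbon would fall. The rest of the core is the same in all four compounds, so they also leave open how far this split would carry over to a changed core.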